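Exchanging fluoro for cyano on the aryl of compound 2

The compounds below may be only part of what the source reports. "The series", "measured", "known", "first", "only" and "open" are said of these compounds alone.

Measured compounds:
compound 1, `CCN(Cc1ccncc1)C(=S)SCc1ccc(C(=O)Nc2ccccc2N)cc1`, 63.5%
compound 2, `Nc1ccccc1NC(=O)c1ccc(CSC(=S)N2CCN(c3ccc(F)cc3)CC2)cc1`, 60.8%
compound 3, `Nc1ccccc1NC(=O)c1ccc(CSC(=S)N2CCCC2)cc1`, 51.3%

Three compounds share the core of compound 1 and were tested in a functional assay on HeLa cells (Homo sapiens) for antiproliferative activity, read by CCK-8 assay, with a stated time of 72 h, tested at 2 uM; a lower number here means a weaker effect, a higher number a stronger effect of the compound at the concentration tested. Compound 1 gives 63.5%, compound 2 gives 60.8% and compound 3 gives 51.3%. Compound 2 stands second highest of the three numbers; its value lies within the scatter of compound 1 and also within the scatter of compound 3, so no order among these three is established by the data. Among the compounds with values here, the one step that differs in a single place, a number 12.2 percentage points lower from compound 1 to compound 3 (beyond the scatter), concerns the group on the thiocarbonyl carbon, not the aryl ring.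

Compound 4, `N#Cc1ccc(N2CCN(C(=S)SCc3ccc(C(=O)Nc4ccccc4N)cc3)CC2)cc1`, differs from compound 2 in one place: cyano in place of fluoro on an aromatic carbon. Within the data shown here, no measured step touches this aryl substituent, so nothing in the data sets a direction for it. Compound 4 is therefore expected to give about 60% in this assay , within 45% to 75%, and the step of a number 0.8 percentage points lower from compound 2 to compound 4 (within the scatter) is expected to stay within the scatter.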

Compound 4, a percentage reported as inhibition, at one concentration (the size of the read-out at that concentration, not a potency): 71.6%
Compound 4: middle estimate off by 11.6 percentage points, on the low side; low and high end bracket the measured number.
By their numbers in this assay, from the lowest: compounds 3, 2, 1 and 4 (each within the scatter of the next, the first and the last beyond it).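

In this assay the change from 4-fluorophenyl to 4-cyanophenyl gives a number 10.8 percentage points higher from compound 2 to compound 4 (beyond the scatter), so the substituent on this aromatic carbon, para to a large group, does bear on the read-out. The earlier compounds shown here showed a single readable step, and it concerned the whole group on the thiocarbonyl carbon; this step shows that exchanging one substituent on the aryl, with everything else held constant, can also move the number beyond the scatter. No measurement at hand accounts for the step, so its cause remains unknown.

Going by these compounds, whether other groups at this place, such as an amine, a carboxylic acid or a methoxy group, would move the number the same way remains open. Also open, on these data alone, is whether the step would hold as a difference in potency, since each number comes from one concentration.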